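Methoxy for fluoro at a second position on the aryl ring

The source may hold more compounds than are shown below. What is called first, only, known or untested is meant among the compounds shown, and "the series" means these compounds.

Measured compounds:
compound 1 `O=[N+]([O-])c1ccc(CN2CCC(n3cc(CC(OCc4cc(-c5ccc(F)cc5)no4)c4ccc(Br)cc4)nn3)CC2)cc1` — > 25000 nM
compound 2 `COc1ccc(-c2cc(COC(Cc3cn(C4CCN(Cc5ccc([N+](=O)[O-])cc5)CC4)nn3)c3ccc(Br)cc3)on2)cc1` — 3000 nM
compound 3 `O=[N+]([O-])c1ccc(CN2CCC(n3cc(CC(OCc4cc(-c5cccc(F)c5)no4)c4ccc(Br)cc4)nn3)CC2)cc1` — 9000 nM

In a functional assay on PC-3 cells (Homo sapiens) for cytotoxicity, with a stated time of 48 h (on this read-out lower numbers stand for stronger inhibition and higher numbers for weaker inhibition), compound 1 reaches only a limit of the method, (the limit of > 25000 nM in this assay, at which 1 of the 3 values shown sits), and not a number. Compound 2 gives 3000 nM in this assay, and compound 3 gives 9000 nM. Compound 2 differs from compound 1 by methoxy in place of fluoro on an aromatic carbon, and this brings an at least 8.3-fold lower number from compound 1 to compound 2 (0.92 log units; beyond the scatter). Compound 3 differs from compound 1 by 3-fluorophenyl in place of 4-fluorophenyl on an aromatic carbon, which brings an at least 2.7-fold lower number from compound 1 to compound 3 (0.44 log units; beyond the scatter); between compound 2 and compound 3 there is a 3.0-fold higher number from compound 2 to compound 3 (0.48 log units; beyond the scatter).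

Compound 4 `COc1cccc(-c2cc(COC(Cc3cn(C4CCN(Cc5ccc([N+](=O)[O-])cc5)CC4)nn3)c3ccc(Br)cc3)on2)c1` is not yet measured. It differs from compound 3 by methoxy in place of fluoro on an aromatic carbon. This is the same kind of change as from compound 1 to compound 2, but not the same: there the group sits para to a large group, here meta to a large group. Because the earlier step was an at least 8.3-fold lower number from compound 1 to compound 2 (0.92 log units; beyond the scatter), a lower number is expected for compound 4 as well, though from compound 3 the step is expected to be a 3.0-fold lower number from compound 3 to compound 4 (0.48 log units; beyond the scatter), smaller than the earlier one since compound 3 already starts from a number rather than a limit. Compound 4 is therefore estimated at 3000 nM, most likely between 1000 nM and 12000 nM.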

Compound 4, half-maximal inhibitory concentration: > 25000 nM
Compound 4: only a limit was reported; the forecaster's own chance of this, stated with the estimate: 5%; at least 8.3-fold (0.92 log units) between middle value and limit.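

In this assay compound 4 reaches > 25000 nM, which is a limit of the assay and not a number. Methoxy in place of fluoro brings an at least 2.7-fold higher number from compound 3 to compound 4 (0.44 log units; beyond the scatter), opposite in direction to the earlier step on the core of compound 1, so this change does not carry over between the two cores, even in its direction: the same change on two cores in this assay, an at least 8.3-fold lower number (0.92 log units; beyond the scatter) from compound 1 to compound 2 and an at least 2.7-fold higher number (0.44 log units; beyond the scatter) from compound 3 to compound 4, at least 23-fold (1.36 log units) apart, beyond the scatter of two such steps Swapping 4-methoxyphenyl for 3-methoxyphenyl brings an at least 8.3-fold higher number from compound 2 to compound 4 (0.92 log units; beyond the scatter), but these steps give only minimum sizes, the step between compound 1 and compound 4 cannot be read, and nothing here shows why the change reverses: the limit of > 25000 nM in this assay, at which 2 of the 4 values shown sit.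

The compounds shown leave open whether an amine or a nitrile on this aromatic ring would give a measurable number, as compound 2 and compound 3 do, or reach the limit, as compound 1 and compound 4 do. They also leave open how methoxy and fluoro compare on any core beyond these two.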